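This account rests on a few compounds, and the source may have more. Where it says the series, first, only, none or still open, it means among the compounds named here.

Measured in a functional assay on cells (Endothelial cell, Bos taurus) for antiproliferative activity (a higher number here means a weaker inhibitor, a lower number a stronger inhibitor), so far

- compound 1 `COc1cc(/C(F)=C/c2cc(O)c3ccsc3c2)cc(OC)c1OC` gives 390 nM
- compound 2 `COc1ccc(/C=C(/F)c2cc(OC)c(OC)c(OC)c2)cc1O` gives 1700 nM

Of these two numbers, compound 2 holds the higher (1700 nM), beyond the scatter from compound 1. Next is compound 3 `COc1ccc(/C=C(\F)c2cc(OC)c(OC)c(OC)c2)cc1O`, an isomer of compound 2 (the two compounds have the same atoms and bonds and differ only in configuration as drawn: 1 of 1 stereo elements differ; a double bond is drawn E in compound 2 and Z in compound 3). Going by the values given here, no measured pair differs in configuration alone, so the data fix neither size nor direction. The expected outcome is no change beyond the scatter, with wide uncertainty either way (a 1.4-fold lower number from compound 2 to compound 3 (0.15 log units; within the scatter)). For compound 3 the estimate is 1200 nM (expected range 100 nM to 8000 nM).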

Compound 3, half-maximal inhibitory concentration: 13000 nM
Estimate against measurement, compound 3: 11-fold (1.03 log units) below; the measured number lies above the stated range.
By their numbers in this assay, from the lowest: compound 1; then compound 2; then compound 3.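

Within this assay the configuration of the double bond is not neutral: drawing it Z rather than E gives a 7.6-fold higher number from compound 2 to compound 3 (0.88 log units; beyond the scatter) on an otherwise unchanged structure. The earlier compounds shown here could not separate this factor, and the shift belongs to the double bond alone because no other feature changes: the fact that compounds 2 and 3 differ only in the configuration as drawn.

From the compounds shown here alone, whether the same order of isomers holds on the core of compound 1 remains open. Also open, going by these compounds, is how an amine or a carboxylic acid in place of the hydroxyl would act in either configuration.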